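This account rests on a few compounds, and the source may have more. Where it says the series, first, only, none or still open, it means among the compounds named here.

Measured compounds:
compound 1 `CN(C)S(=O)(=O)c1ccc(Nc2ccc(C(=O)c3c(F)cccc3F)c(N)n2)cc1` – > 10000 nM
compound 2 `Nc1nc(Nc2ccc(S(N)(=O)=O)cc2)ccc1C(=O)c1c(F)cccc1F` – 16500 nM

In a functional assay on HCT-116 cells (Homo sapiens) for antiproliferative activity (on this read-out lower numbers stand for stronger inhibition and higher numbers for weaker inhibition), compound 1 gives only > 10000 nM, which is a limit of the assay rather than a number. In this assay, going by the values given here, compound 2 gives 16500 nM, the only true number among the two values shown. The step from compound 1 to compound 2 is therefore a step that the limit leaves unreadable from compound 1 to compound 2, a change of amino in place of dimethylamino on a sulfonyl sulfur; it is not a readable step, as the limit of > 10000 nM in this assay, at which 1 of the 2 values shown sits, sets a ceiling on what can be seen. Compound 3 `CCCCOc1cc(Nc2ccc(S(N)(=O)=O)cc2)nc(N)c1C(=O)c1c(F)cccc1F` has not yet been measured in this assay. It differs from compound 2 by butoxy in place of hydrogen on an aromatic carbon, so butoxy in place of hydrogen on an aromatic carbon, ortho to the (2,6-difluorophenyl)carbonyl group. No measured step concerns this kind of change, and the one step shown is unreadable. With nothing to lean on, the expected step from compound 2 to compound 3 is a 1.4-fold lower number from compound 2 to compound 3 (0.14 log units; within the scatter), no direction beyond the scatter. Compound 3 is estimated at 12000 nM, in a wide range from 2500 nM to 50000 nM.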

Compound 3, half-maximal inhibitory concentration: 6700 nM
Compound 3: middle estimate off by 1.8-fold (0.25 log units), on the high side, within the range that was stated.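

Going by these compounds alone, this is the first step that can be read, and it falls on the aromatic carbon ortho to the (2,6-difluorophenyl)carbonyl group and opposite the ring nitrogen. In this assay, butoxy in place of hydrogen at this carbon gives a 2.5-fold lower number from compound 2 to compound 3 (0.39 log units; beyond the scatter), so a chain of this size can sit here and the number moves toward stronger inhibition, not weaker. The only earlier step concerned the sulfonyl sulfur, at the other end of the molecule, and it cannot be read, so it said nothing about the size of any change: the limit of > 10000 nM in this assay, at which 1 of the 3 values shown sits.

The compounds shown leave open why the number falls, since a single step cannot separate the part played by the oxygen attached to the ring from the part played by the chain that follows it. Whether a shorter methoxy, a longer hexyloxy chain or an amine at the same carbon would move the number further, or reverse the step, also remains unanswered, as does whether the same step would hold with the dimethylamino group on the sulfonyl sulfur.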